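Extending a long chain on a lymphocyte-active phenol

The compounds below may be only part of what the source reports. "The series", "measured", "known", "first", "only" and "open" are said of these compounds alone.

Compound 1 `CCCCCCCCCCCCCCCCc1c(C)c(N(C)C)nc(C)c1O`: 96%
Compound 2 `CCCCCCCCCCCCCCCCc1nc(N2CCC2)c(C)c(C)c1O`: 92%

In a functional assay on cells (Lymphocyte), read by a luciferase reporter and ATP content, with a stated time of 48 h, tested at 5 uM (on this read-out lower numbers stand for a stronger effect and higher numbers for a weaker effect at the one concentration tested), compound 1 gives 96%, the higher of the two numbers, while compound 2 gives 92%; the gap between them lies within the scatter, so neither can be called the stronger. Compound 3 `CCCCCCCCCCCCCCCCCCCc1c(C)c(N(C)C)nc(C)c1O` differs from compound 1 only by propyl in place of hydrogen on a saturated chain carbon, ten or more bonds along the chain from an aromatic carbon. Among the compounds with values here, no step between measured compounds shows what such a lengthening does. The step from compound 1 to compound 3 is therefore expected to stay within the scatter, a number 1 percentage points lower from compound 1 to compound 3 (within the scatter), in no clear direction. Compound 3 is expected to give about 95%, between 84% and 106%.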

Compound 3, a percentage reported as activity, at one concentration (the size of the read-out at that concentration, not a potency): 106%
Compound 3: the middle estimate sits 11 percentage points below what was measured; low and high end bracket the measured number.
By their numbers in this assay, from the lowest: compounds 2, 1 and 3 (each within the scatter of the next, the first and the last beyond it).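

In this assay propyl in place of hydrogen on a saturated chain carbon, ten or more bonds along the chain from an aromatic carbon, gives a number 10 percentage points higher from compound 1 to compound 3 (within the scatter) and so no clear effect. Within the data shown here, this is the first direct look at this far part of the chain, and at this one concentration the lengthening does not separate the two compounds. Nothing available here offers an explanation for this result.

Going by these compounds, whether a still longer chain would give a clear step remains open. So does the effect of an amine or a carboxylic acid placed at this far end of the chain.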